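Working notes: aryl swap from compound 3 to compound 4

This account rests on a few compounds, and the source may have more. Where it says the series, first, only, none or still open, it means among the compounds named here.

Measured so far in a functional assay on Hs-578T cells (Homo sapiens) for inhibition, read by sulforhodamine B assay, with a stated time of 48 h, tested at 10 uM; on this read-out higher numbers stand for more inhibition at the one concentration tested (going by the name of the read-out) and lower numbers for less inhibition:
compound 1 `c1ccc(-c2cn3ccnc3c(-c3ccc4ncn(C5CCCCC5)c4c3)n2)cc1` — 23.8%
compound 2 `COc1ccc(-c2cn3ccnc3c(-c3ccc4ncn(C5CCCCC5)c4c3)n2)cc1` — 80%
compound 3 `c1ccc2c(-c3cn4ccnc4c(-c4ccc5ncn(C6CCCCC6)c5c4)n3)cccc2c1` — 3.62%

Compound 3 stands lowest of the three numbers; its nearest neighbour is compound 1 and compound 2 lies furthest from it, both gaps beyond the scatter. Compound 4 `Fc1ccc(-c2cn3ccnc3c(-c3ccc4ncn(C5CCCCC5)c4c3)n2)cc1` is not yet measured. Its change from compound 3: 4-fluorophenyl in place of naphthalen-1-yl on an aromatic carbon. The naphthalen-1-yl leaves and a 4-fluorophenyl enters at the same aromatic carbon.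

For the measured compounds named here, two measured steps bear on this, both running toward compound 3 and both downward: a number 20.2 percentage points lower from compound 1 to compound 3 (beyond the scatter) and a number 76.4 percentage points lower from compound 2 to compound 3 (beyond the scatter). Compound 4 runs the other way, away from naphthalen-1-yl toward a single six-membered ring, so a rise is expected in this assay. Going by the values given here, how large is open: the numbers for compound 1 and compound 2 span a wide band, and no measured step joins 4-fluorophenyl to either phenyl or 4-methoxyphenyl. The estimate is placed between those two anchors, nearer the lower one, with a wide range. For compound 4 the expected step is a number 31.4 percentage points higher from compound 3 to compound 4 (beyond the scatter), upward and beyond the scatter. Compound 4 is expected to give about 35% in this assay, estimated range 10% to 70%.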

Compound 4, a percentage reported as inhibition, at one concentration (the size of the read-out at that concentration, not a potency): 17.6%
Estimate against measurement, compound 4: 17.4 percentage points above, within the range that was stated.
By their numbers in this assay, from the lowest: compound 3; then compounds 4 and 1 (each within the scatter of the next); then compound 2.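

In this assay, fluoro in place of hydrogen on the phenyl ring gives no readable change, a number 6.2 percentage points lower from compound 1 to compound 4 (within the scatter), so the large rise seen with methoxy is not shared by every replacement of that hydrogen. Fluoro in place of methoxy removes most of the signal, a number 62.4 percentage points lower from compound 2 to compound 4 (beyond the scatter), which ties the high number, among the compounds shown, to the methoxy group itself rather than to the mere presence of a substituent on that ring. 4-Fluorophenyl in place of naphthalen-1-yl gives only a modest gain, a number 14 percentage points higher from compound 3 to compound 4 (beyond the scatter), so leaving the two-ring naphthalen-1-yl for a single six-membered aromatic ring does not by itself restore a high number.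

The compounds shown leave open whether a group such as ethoxy, hydroxyl or dimethylamino on this ring would keep the high number or whether it is confined to methoxy. No measurement at hand gives a reason for any of these steps, so the differences stand as observations only.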